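Oxime carbamates and coffee alpha-galactosidase: a methylsulfanyl analogue

This account rests on a few compounds, and the source may have more. Where it says the series, first, only, none or still open, it means among the compounds named here.

Compound 1, `OC[C@H]1N/C(=N/O)[C@H](O)[C@@H](O)[C@@H]1O`: in an assay on isolated protein for inhibition of alpha-galactosidase (Coffea arabica) (a lower number here means a stronger inhibitor, a higher number a weaker inhibitor), compound 1 gives > 100000 nM, which is a limit of the assay and not a number.
Compound 2, `O=C(Nc1ccccc1)O/N=C1\N[C@H](CO)[C@@H](O)[C@H](O)[C@H]1O`: in this assay compound 2 gives > 100000 nM, again a limit rather than a number.
Compound 3, `O=C(Nc1ccc(Oc2ccccc2)cc1)O/N=C1\N[C@H](CO)[C@@H](O)[C@H](O)[C@H]1O`: in this assay compound 3 gives > 100000 nM, also a limit.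

All three compounds share the core of compound 1; compounds 2 and 3 extend it by a larger substituent that carries a six-membered aromatic ring of carbon only. None of them reaches a measurable inhibition: every value sits at the same limit, as the limit of > 100000 nM in this assay, at which 3 of the 3 values shown sit, shows. Among the compounds with values here, the only single-point change among the measured compounds, a step that the two limits leave unreadable from compound 2 to compound 3, is therefore unreadable in size. Compound 3 stands where every other compound stands, at the limit, with no number to rank it.

Compound 4, `CSc1ccc(NC(=O)O/N=C2\N[C@H](CO)[C@@H](O)[C@H](O)[C@H]2O)cc1`, differs from compound 3 by methylsulfanyl in place of phenoxy on an aromatic carbon. Within the data shown here, no measured step can be read for this kind of exchange, and the one step that exists between compounds 2 and 3 gives no direction either. The expectation is that compound 4 will again show no measurable inhibition, so the expected step that the limit leaves unreadable from compound 3 to compound 4 is none that can be read. Compound 4 is estimated at 150000 nM, with a range from 50000 nM to 1000000 nM.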

Compound 4, half-maximal inhibitory concentration: > 100000 nM
Compound 4: only a limit was reported (the forecaster's own chance of this, stated with the estimate: 85%); the middle value lies beyond the limit too.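

In this assay compound 4 gives > 100000 nM, which is a limit of the assay and not a number. The steps from compound 2 and compound 3 to compound 4 therefore cannot be read, since all the compounds rest at one limit: the limit of > 100000 nM in this assay, at which 4 of the 4 values shown sit. The compounds shown leave open whether any substituent on this shared core gives measurable inhibition.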